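The source may report more compounds than this note shows. Statements on the series, on what has been measured and on what is new or still open speak of the compounds shown alone.

Compound 1 `CC(C)=CCc1ccc2c(c1O)C(=O)CC(c1ccccc1O)O2` gives 1250 nM in an assay on HEK293 cells for inhibition of Voltage-dependent T-type calcium channel subunit alpha-1H (Homo sapiens), read by patch clamp, with a stated time of 10 min; on this read-out lower numbers stand for stronger inhibition and higher numbers for weaker inhibition.
Compound 2 `CC(C)=CCc1c(O)cc2c(c1O)C(=O)CC(c1ccccc1O)O2` gives 640 nM in this assay.
Compound 3 `CCC(=CCc1c(O)cc2c(c1O)C(=O)CC(c1ccccc1O)O2)CC` gives 390 nM in this assay.

Compound 3 holds the lowest number of the three. Its neighbour is compound 2, separated by a step within the scatter, and compound 1 sits furthest off, beyond the scatter. The two single-place steps measured so far are a 2.0-fold lower number from compound 1 to compound 2 (0.29 log units; within the scatter) and a 1.6-fold lower number from compound 2 to compound 3 (0.22 log units; within the scatter), each within the scatter on its own; only their sum, read between compound 1 and compound 3, clears it.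

Compound 4 `CCC(=CCc1c(O)cc2c(c1O)C(=O)CC(c1ccc(O)cc1)O2)CC` differs from compound 3 in one place: 4-hydroxyphenyl in place of 2-hydroxyphenyl on a saturated ring carbon. Neither measured step touches this ring; both alter the other end of the shared core, the hydroxy on the aromatic carbon and the chain on the saturated carbon. Among the measured compounds shown here, no measured pair therefore bears on moving the hydroxy around the phenyl ring, and nothing in the data argues for a change beyond the scatter. The estimated step of a 1.3-fold higher number from compound 3 to compound 4 (0.11 log units; within the scatter) is accordingly a small one. Compound 4 is expected to give about 500 nM in this assay, within a range from 200 nM to 1500 nM.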

Compound 4, half-maximal inhibitory concentration: 260 nM
Compound 4: middle estimate off by 1.9-fold (0.28 log units), on the high side; measured number inside the range.
By their numbers in this assay, from the lowest: compounds 4, 3, 2 and 1 (each within the scatter of the next, the first and the last beyond it).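

In this assay, the change of 2-hydroxyphenyl to 4-hydroxyphenyl on the saturated ring carbon next to the ring oxygen gives a 1.5-fold lower number from compound 3 to compound 4 (0.18 log units; within the scatter), and it is the first step shown at this position. The earlier steps shown here all lay at the other end of the shared core, so this one adds that the hydroxy can occupy either of these two places on the phenyl ring without a step beyond the scatter. Nothing measured gives a reason for this step. On these data alone, what a different group would do at this position stays open, for example a methoxy, an amine or a carboxylic acid on the phenyl ring, or a plain phenyl. Also open, as far as these compounds go, is whether 4-hydroxyphenyl would give a similar result alongside the shorter chain of compound 2.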